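A Second Chloro Group on a Shared Core

This account rests on a few compounds, and the source may have more. Where it says the series, first, only, none or still open, it means among the compounds named here.

Compound 1 `ClCc1ccc(Cn2cnc3c(Cl)ncnc32)cc1` and compound 2 `ClCc1ccccc1Cn1cnc2ncnc(Cl)c21` are made of the same atoms joined differently; the difference between the two cores is not broken down here. Both were tested in a functional assay on HCT-15 cells (Homo sapiens) for cytotoxicity, read by sulforhodamine B assay, with a stated time of 48 h; a higher number here means a weaker inhibitor of growth, a lower number a stronger inhibitor of growth. In this assay compound 1 gives 1950 nM, and compound 2 gives 1380 nM. Compound 3 `ClCc1ccc(Cn2cnc3c(Cl)nc(Cl)nc32)cc1` is compound 1 with one change: chloro in place of hydrogen on an aromatic carbon. In this assay compound 3 gives 1860 nM, so the step was a 1.0-fold lower number from compound 1 to compound 3 (0.02 log units; within the scatter). Compound 4 `ClCc1ccccc1Cn1cnc2nc(Cl)nc(Cl)c21` has not yet been measured. It stands to compound 2 as compound 3 stands to compound 1: chloro in place of hydrogen on an aromatic carbon. The change is the same in both pairs, and the surroundings of the place are described in the same words. Because the earlier step was a 1.0-fold lower number from compound 1 to compound 3 (0.02 log units; within the scatter), the same change is expected to give a 1.0-fold lower number from compound 2 to compound 4 (0.01 log units; within the scatter). That expectation rests on a single measured precedent. Compound 4 is therefore estimated at 1350 nM, most likely between 700 nM and 2600 nM.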

Compound 4, concentration for 50% growth inhibition: 190 nM
Compound 4: middle estimate off by 7.1-fold (0.85 log units), on the high side; measured number below the stated range.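

In this assay, putting chloro in place of hydrogen on the core of compound 2 gave a 7.3-fold lower number from compound 2 to compound 4 (0.86 log units; beyond the scatter), so here the added chloro group went with stronger growth inhibition. The same change did not carry over evenly from one core to the other: the same change on two cores in this assay, a 1.0-fold lower number (0.02 log units; within the scatter) from compound 1 to compound 3 and a 7.3-fold lower number (0.86 log units; beyond the scatter) from compound 2 to compound 4, 6.9-fold (0.84 log units) apart, beyond the scatter of two such steps In this series, then, a step measured on one core was a poor guide to the same step on the other, but these two pairs do not show why the cores part ways, and two pairs give no rule for any further core.

The compounds shown leave open whether a different group in the same place, between two ring nitrogen atoms, such as an amine or a methoxy group, would also give a lower number on the core of compound 2 or would leave it unchanged as on the core of compound 1. They also leave open whether the gap between the two steps would hold in cells other than these.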